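Adding a Methoxy Group: Expected Cytotoxicity of Compound 3

A few compounds are considered here, and "the series" means these few. Any claim that something is new, unique, unknown or untested is made for them only; others in the source may bear on it.

Two esters have so far been measured in a functional assay on EA.hy 926 cells (Homo sapiens) for cytotoxicity, read by MTT assay, with stated times of 24 h and 12 h, tested at 100 uM; a lower number here means a weaker effect, a higher number a stronger effect of the compound at the concentration tested. Compound 1 `CCOC(=O)/C=C/c1ccccc1OC(=O)c1nc(C)c(C)nc1C` gives 40.9%, while compound 2 `Cc1nc(C)c(C(=O)Oc2cccc(/C=C/C(=O)O)c2)nc1C` gives 103%, the higher of the two numbers and beyond the scatter above compound 1. Compound 3 `COc1ccc(/C=C/C(=O)O)cc1OC(=O)c1nc(C)c(C)nc1C` differs from compound 2 by methoxy in place of hydrogen on an aromatic carbon. Going by the values given here, no pair of measured compounds shows this change, so its effect is untested in this set. In this assay the expected step is a number 8 percentage points lower from compound 2 to compound 3 (within the scatter), not beyond the usual scatter. Compound 3 is estimated at 95%, with a range from 70% to 110%.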

Compound 3, a percentage reported as activity, at one concentration (the size of the read-out at that concentration, not a potency): 216%
Estimate against measurement, compound 3: 121 percentage points below, outside the stated range (above it).
By their numbers in this assay, from the lowest: compound 1; then compound 2; then compound 3.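

In this assay, methoxy in place of hydrogen on an aromatic carbon gives a number 113 percentage points higher from compound 2 to compound 3 (beyond the scatter), the first reading of this change among these compounds. This carbon, ortho to a large group and para to a 2-carboxyethenyl group, is therefore a place where 2 heavy atoms can shift the read-out well beyond the scatter. Nothing available here explains the size of this step.

From the compounds shown here alone, whether a hydroxy group or an ethoxy group on the same carbon would give a similar step remains open. So does whether methoxy would have the same effect on another carbon of this ring.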